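Aryl swaps on the phenethoxy tail: rat microsomal stability

This account rests on a few compounds, and the source may have more. Where it says the series, first, only, none or still open, it means among the compounds named here.

Measured compounds:
- compound 1 `COc1ccc(CCOc2ccc(-c3c(C)nc(C)c([C@H](OC(C)(C)C)C(=O)O)c3N3CCC(C)(C)CC3)cc2)cc1`: > 2 h in an ADME assay on microsomes from liver (Rattus norvegicus) for metabolic stability, read by LC-MS, tested at 0.5 uM; on this read-out higher numbers stand for a longer-lived compound and lower numbers for a shorter-lived compound; this value is a limit of the assay
- compound 2 `Cc1cc(CCOc2ccc(-c3c(C)nc(C)c([C@H](OC(C)(C)C)C(=O)O)c3N3CCC(C)(C)CC3)cc2)ccc1F`: > 2 h in this assay; this value is a limit of the assay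
- compound 3 `Cc1nc(C)c([C@H](OC(C)(C)C)C(=O)O)c(N2CCC(C)(C)CC2)c1-c1ccc(OCCc2ccc(F)cc2F)cc1`: > 2 h in this assay; this value is a limit of the assay

Compound 1 stands only at a limit in this assay, and the same holds for the two other measured compounds: the limit of > 2 h in this assay, at which 3 of the 3 values shown sit. The three steps among them, a step that the two limits leave unreadable from compound 1 to compound 2, a step that the two limits leave unreadable from compound 1 to compound 3 and a step that the two limits leave unreadable from compound 2 to compound 3, are therefore all unreadable in size and direction.

The next compound, compound 4 `Cc1nc(C)c([C@H](OC(C)(C)C)C(=O)O)c(N2CCC(C)(C)CC2)c1-c1ccc(OCCc2ccc(F)c(F)c2)cc1`, differs from compound 1 by 3,4-difluorophenyl in place of 4-methoxyphenyl on a saturated chain carbon, two bonds along the chain from an oxygen on an aromatic ring. Within the data shown here, no measured step gives a readable size for this kind of change; the three steps above bear on it only in that every aryl variant so far reached the limit. Compound 4 is therefore expected to show a step that the limit leaves unreadable from compound 1 to compound 4, with no readable movement away from the limit in this assay. Compound 4 is expected to give 3 h, estimated between 1.5 h and 8 h.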

Compound 4, half-life: 0.85 h
Compound 4: middle estimate off by 3.5-fold (0.55 log units), on the high side, outside the stated range (below it).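

Among these compounds, compound 4 is the first aryl variant on the phenethoxy tail to give a readable number in this assay, and it shows that the aryl group at this position can change the read-out: 3,4-difluorophenyl gives an at least 2.3-fold lower number from compound 1 to compound 4 (0.37 log units; beyond the scatter) against 4-methoxyphenyl and an at least 2.3-fold lower number from compound 3 to compound 4 (0.37 log units; beyond the scatter) against 2,4-difluorophenyl. One change on that ring is enough, as fluoro in place of methyl on an aromatic carbon gives an at least 2.3-fold lower number from compound 2 to compound 4 (0.37 log units; beyond the scatter). Compound 1, compound 2 and compound 3 each stand only at a limit, so these steps are minimum sizes: the limit of > 2 h in this assay, at which 3 of the 4 values shown sit.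

As far as these compounds go, how far those three compounds lie past the limit stays open, and so does the full size of each step. From the compounds shown here alone, it is also open whether a 3-fluorophenyl or a 4-fluorophenyl group on the same chain would give a readable number in this assay.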